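A few compounds are considered here, and "the series" means these few. Any claim that something is new, unique, unknown or untested is made for them only; others in the source may bear on it.

Measured in a functional assay on CWR22R cells (Homo sapiens) for cytotoxicity, read by MTT assay, with a stated time of 72 h; a higher number here means a weaker inhibitor, a lower number a stronger inhibitor:
compound 1 `CC1=C(/C=C/C(=O)/C=C/c2ccc(C(F)(F)F)cc2)C(C)(C)CCC1O` gives 3200 nM;
compound 2 `CC1=C(/C=C/C(=O)/C=C/c2ccc(F)cc2)C(C)(C)CCC1O` gives 7500 nM;
compound 3 `CC1=C(/C=C/C(=O)/C=C/c2ccc([N+](=O)[O-])cc2)C(C)(C)CCC1O` is not yet measured.

Compound 2 has the highest number of the two, its nearest neighbour being compound 1, which differs only in the group on the aromatic ring. The change from compound 2 to compound 3 is nitro in place of fluoro on an aromatic carbon. Among the compounds with values here, the one measured step that bears on it, a 2.3-fold higher number from compound 1 to compound 2 (0.37 log units; beyond the scatter), shows that swapping this para group can move the number modestly. A similar modest move in this assay is expected, a 1.9-fold lower number from compound 2 to compound 3 (0.27 log units; within the scatter), since nitro is also a larger group than fluoro. Compound 3 is therefore estimated at 4000 nM, within 1500 nM to 12000 nM.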

Compound 3, half-maximal inhibitory concentration: 4100 nM
Compound 3: middle estimate off by 1.0-fold (0.01 log units), on the low side; measured number inside the range.
By their numbers in this assay, from the lowest: compounds 1, 3 and 2 (each within the scatter of the next, the first and the last beyond it).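

In this assay, nitro on this aromatic carbon cannot be told apart from fluoro (a 1.8-fold lower number from compound 2 to compound 3 (0.26 log units; within the scatter)) or from trifluoromethyl (a 1.3-fold higher number from compound 1 to compound 3 (0.11 log units; within the scatter)). Compound 3 therefore sits within the scatter of both neighbours, and the step from compound 1 to compound 2 (a 2.3-fold higher number from compound 1 to compound 2 (0.37 log units; beyond the scatter)) remains the only one beyond it. Nothing measured here offers a reason for these numbers.

As far as these compounds go, whether an amine or a carboxylic acid in this place would give a step beyond the scatter remains open. So does the effect of moving any of these groups elsewhere on the ring.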